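Series notes: ring-amine substituent exchange from compound 2 to compound 3

The compounds below may be only part of what the source reports. "The series", "measured", "known", "first", "only" and "open" are said of these compounds alone.

Measured so far:
compound 1 `CC(C)(C)OC(=O)N1CCC(O[C@H]2CC[C@@H](Oc3ccc(S(C)(=O)=O)cc3)CC2)CC1`: 120%
compound 2 `C[C@@H](CF)OC(=O)N1CCC(O[C@H]2CC[C@H](Oc3cnc(S(C)(=O)=O)cn3)CC2)CC1`: 105%

Both compounds were run in a functional assay on isolated protein for agonist activity at Glucose-dependent insulinotropic receptor (Homo sapiens), read by HTRF and cAMP accumulation; on this read-out higher numbers stand for larger maximal responses and lower numbers for smaller maximal responses. Compound 1 reaches 120%, compound 2 reaches 105%. Compound 2 thus stands lowest of the two numbers, with compound 1 the nearest neighbour at a value higher by a margin that lies beyond the usual scatter. For the measured compounds named here, no single-point step between measured compounds is available, so nothing is known yet about how changes on the ring amine nitrogen shift the maximal response.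

Compound 3 `CS(=O)(=O)c1cnc(O[C@H]2CC[C@H](OC3CCN(CC4(C(F)(F)F)CCCC4)CC3)CC2)cn1` is the next candidate. Compared with compound 2 it differs as follows (a group of 10 heavy atoms (7 carbon, 3 fluorine; one five-membered non-aromatic ring of carbon only) in place of a group of 7 heavy atoms (4 carbon, 2 oxygen, 1 fluorine; no ring), on an amine nitrogen in a ring). Since both measured values sit at or above the reference level, the maximal response is expected to stay near that level, and the step from compound 2 to compound 3 is expected to be a number 5 percentage points lower from compound 2 to compound 3 (within the scatter), none beyond the scatter. For compound 3 the expected value in this assay is 100%, within a range of 80% to 120%.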

Compound 3, largest response reached (Emax), in percent of the reference or control that the assay uses: 37%
Compound 3: middle estimate off by 63 percentage points, on the high side; measured number outside the range, below it.
By their numbers in this assay, from the lowest: compound 3; then compound 2; then compound 1.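

In this assay, the group of 10 heavy atoms with one five-membered non-aromatic ring of carbon only, in place of the group of 7 heavy atoms with no ring, gives a number 68 percentage points lower from compound 2 to compound 3 (beyond the scatter) on the amine nitrogen in a ring. For the compounds shown here, this is the first single-place step, and it shows that the maximal response does not hold near the level of compound 2 whatever group this nitrogen carries. No measurement at hand accounts for the size of this step.

The compounds shown leave open which part of the exchange carries the step: the departure of the group with its double bond and hydrogen-bond acceptors, or the arrival of the carbon ring with its fluorines. A urea or a simple cyclopentylmethyl group on the same nitrogen would help to separate these two parts.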